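A few compounds are considered here, and "the series" means these few. Any claim that something is new, unique, unknown or untested is made for them only; others in the source may bear on it.

In a functional assay on HepG2 cells (Homo sapiens) for antiproliferative activity, read by MTT assay, with a stated time of 48 h (on this read-out lower numbers stand for stronger inhibition and higher numbers for weaker inhibition), compound 1 `OC(/C=C/c1cccc(Cl)c1)c1nc2ccccc2[nH]1` gives only a limit of the assay, > 100000 nM. Compound 2 `COc1cccc(/C=C/C(O)c2nc3ccccc3[nH]2)c1` likewise gives only a limit, > 100000 nM. The step that the two limits leave unreadable from compound 1 to compound 2 is made by methoxy in place of chloro on an aromatic carbon, and its size cannot be read, as the limit of > 100000 nM in this assay, at which 3 of the 3 values shown sit, shows. Compound 3 `O=C(/C=C/c1cccc(Cl)c1)c1nc2ccccc2o1` also gives only a limit in this assay, > 100000 nM. How the core of compound 3 differs from the core of compound 1 is not broken down here. Compound 4 `COc1cccc(/C=C/C(=O)c2nc3ccccc3o2)c1` differs from compound 3 by methoxy in place of chloro on an aromatic carbon, the same change as that from compound 1 to compound 2. On the unreadable step that the two limits leave unreadable from compound 1 to compound 2 alone, the expected step is a step that the limit leaves unreadable from compound 3 to compound 4. Compound 4 is thus estimated at 150000 nM, with a range from 50000 nM to 500000 nM, and is expected most likely to return itself only a limit.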

Compound 4, half-maximal inhibitory concentration: > 100000 nM
Compound 4: a limit, no number; the forecaster's own chance of this, stated with the estimate: 85%; the middle value is on the limit's open side.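

The step from compound 3 to compound 4 cannot be read, as both give only a limit and no number: the limit of > 100000 nM in this assay, at which 4 of the 4 values shown sit. The compounds shown leave open whether methoxy in place of chloro on an aromatic carbon changes the result in this assay at all.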